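The compounds below may be only part of what the source reports. "The series", "measured", "known", "first", "only" and "open" are said of these compounds alone.

Compounds measured so far in a functional assay on HCT-116 cells (Homo sapiens) for cytotoxicity, read by MTT assay, with a stated time of 48 h; on this read-out lower numbers stand for stronger inhibition and higher numbers for weaker inhibition:
compound 1 `O=C(c1cc(Oc2cccc(NC(=S)Nc3ccc(F)c(F)c3)c2)ccn1)N1CCCC1`: 52000 nM
compound 2 `O=C(c1cc(Oc2cccc(NC(=S)Nc3ccc(Cl)c(C(F)(F)F)c3)c2)ccn1)N1CCCC1`: 22400 nM
compound 3 `O=C(NCc1ccccc1)c1cc(Oc2cccc(NC(=S)Nc3ccc(OC(F)(F)F)cc3)c2)ccn1`: 7400 nM

Compound 3 stands lowest of the three, beyond the scatter from both neighbours. Compound 4 `O=C(c1cc(Oc2cccc(NC(=S)Nc3ccc(OC(F)(F)F)cc3)c2)ccn1)N1CCCC1` differs from compound 3 in one place: pyrrolidin-1-yl in place of benzylamino on a carbonyl carbon. Among the compounds with values here, no measured step changes this amide group alone; the only measured step, a 2.3-fold lower number from compound 1 to compound 2 (0.37 log units; beyond the scatter), alters the ring on the thiourea instead. Compounds 1 and 2 do carry the pyrrolidin-1-yl group of compound 4 and give higher numbers than compound 3, but their thiourea rings also differ, so that comparison is mixed. A modest rise is therefore expected, with wide uncertainty. Compound 4 is estimated at 15000 nM, between 5000 nM and 45000 nM, an expected step of a 2.0-fold higher number from compound 3 to compound 4 (0.31 log units; beyond the scatter).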

Compound 4, half-maximal inhibitory concentration: 17800 nM
Estimate against measurement, compound 4: 1.2-fold (0.07 log units) below; measured number inside the range.
By their numbers in this assay, from the lowest: compound 3; then compounds 4 and 2 (each within the scatter of the next); then compound 1.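

In this assay, the group on the carbonyl carbon matters on its own: pyrrolidin-1-yl in place of benzylamino gives a 2.4-fold higher number from compound 3 to compound 4 (0.38 log units; beyond the scatter), with the rest of the molecule unchanged. With pyrrolidin-1-yl kept, 4-(trifluoromethoxy)phenyl on the amide-type nitrogen gives a 2.9-fold lower number from compound 1 to compound 4 (0.47 log units; beyond the scatter) against 3,4-difluorophenyl, and a 1.3-fold lower number from compound 2 to compound 4 (0.10 log units; within the scatter) against 4-chloro-3-(trifluoromethyl)phenyl, so these last two rings cannot be separated here. No measurement shown explains these differences. Still open, as far as these compounds go, is whether benzylamino owes its lower number to its aromatic ring or to the amide hydrogen. Cyclohexylmethylamino and N-methylbenzylamino groups would separate these two features.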